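Methoxy Position Swap Carried From One Core to Another

The compounds below may be only part of what the source reports. "The series", "measured", "known", "first", "only" and "open" are said of these compounds alone.

Three compounds were measured in a functional assay on HepG2 cells (Homo sapiens) for antiproliferative activity; a lower number here means a stronger inhibitor, a higher number a weaker inhibitor:
compound 1 `COc1cccc(/C=C/C(=O)c2ccc(OCCn3cc(CN4C(=O)/C=C/C(C)(C)C/C=C(\C)CC/C=C/4C)nn3)cc2O)c1` gives 1.01 ug/mL
compound 2 `COc1ccccc1/C=C/C(=O)c1ccc(OCCn2cc(CN3C(=O)/C=C/C(C)(C)C/C=C(\C)CC/C=C/3C)nn2)cc1O` gives 1.71 ug/mL
compound 3 `COc1cccc(/C=C/C(=O)c2ccc(OCCCN3C(=O)/C=C/C(C)(C)C/C=C(\C)CC/C=C/3C)cc2)c1` gives 1.38 ug/mL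

Compound 1 and compound 2 share a core and differ by 2-methoxyphenyl in place of 3-methoxyphenyl on a double-bonded chain carbon bound to a double-bonded chain carbon. That change gave a 1.7-fold higher number from compound 1 to compound 2 (0.23 log units; within the scatter) in this assay, so the two numbers sit within the scatter of each other and no order between them can be claimed.

Compound 3 carries a different core; how the core of compound 3 differs from the core of compound 1 is not broken down here. Among the measured compounds shown here, compound 4 `COc1ccccc1/C=C/C(=O)c1ccc(OCCCN2C(=O)/C=C/C(C)(C)C/C=C(\C)CC/C=C/2C)cc1` is built from compound 3 by 2-methoxyphenyl in place of 3-methoxyphenyl on a double-bonded chain carbon bound to a double-bonded chain carbon, the same change, at the same place, as the one between compound 1 and compound 2.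

With only this single earlier pairing to rest on, the step from compound 3 to compound 4 in this assay is expected to be about a 1.4-fold higher number from compound 3 to compound 4 (0.16 log units; within the scatter), because a 1.7-fold higher number from compound 1 to compound 2 (0.23 log units; within the scatter) was the outcome of the same change on the other core. On that basis compound 4 is estimated at 2 ug/mL, between 1 ug/mL and 4 ug/mL.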

Compound 4, half-maximal inhibitory concentration: 1.44 ug/mL
The estimate for compound 4 lay 1.4-fold (0.14 log units) above the measured number; measured number inside the range.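

On the core of compound 3, 2-methoxyphenyl in place of 3-methoxyphenyl gave a 1.0-fold higher number from compound 3 to compound 4 (0.02 log units; within the scatter) in this assay, so no order can be claimed within this pair. Set beside the earlier pairing, the two steps do not differ: the same change on two cores in this assay, a 1.7-fold higher number (0.23 log units; within the scatter) from compound 1 to compound 2 and a 1.0-fold higher number (0.02 log units; within the scatter) from compound 3 to compound 4, 1.6-fold (0.21 log units) apart, within the scatter of two such steps. In both pairs the swap left the numbers within the scatter of each other, so the outcome carried over from one core to the other in these four compounds, but this does not give the change a measurable effect or direction of its own, and two pairs do not make a rule for the whole series.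

The compounds shown leave open what an amine or a carboxylic acid would do in place of the methoxy group on this phenyl ring. They also leave open whether the swap would stay this small on a core with a longer chain.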